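The source may report more compounds than this note shows. Statements on the series, on what has been measured and on what is new or still open speak of the compounds shown alone.

Measured compounds:
Compound 1 `COc1ccc(C2=NN(C3=NC(=O)/C(=C4\C(=O)Nc5ccc(Cl)cc54)S3)C(c3ccc(Cl)cc3)C2)cc1` gives 460 nM in a functional assay on cells (Cancer cell lines, Homo sapiens) for cytotoxicity, read by sulforhodamine B assay, with a stated time of 48 h; a lower number here means a stronger inhibitor of growth, a higher number a weaker inhibitor of growth.
Compound 2 `COc1ccc(-c2cc(-c3ccc(Cl)cc3)n(C3C(=O)Nc4ccc(Br)cc43)n2)cc1` gives 32300 nM in this assay.
Compound 3 `COc1ccc(-c2cc(-c3ccc(Cl)cc3)n(C3C(=O)Nc4ccc(Cl)cc43)n2)cc1` gives 13200 nM in this assay.

Among these three, compound 2 stands at the highest number. Its nearest neighbour is compound 3, reached by a 2.4-fold lower number from compound 2 to compound 3 (0.39 log units; beyond the scatter), a modest step that rests on a single exchange of halogen. Within the data shown here, the largest gap separates compound 2 from compound 1, whose structure differs in its core rather than in one group, so the two values show only that compound 1 sits far lower.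

Compound 4 `O=C1Nc2ccc(Br)cc2C1n1nc(-c2ccc3ccccc3c2)cc1-c1ccc(Cl)cc1` has not yet been measured. It differs from compound 2 by naphthalen-2-yl in place of 4-methoxyphenyl on an aromatic carbon. Among the measured compounds shown here, no measured pair among the three compounds shares this change: the only single-point step, the one from compound 2 to compound 3, concerns the halogen on the lactam-bearing ring and not the aryl group on the pyrazole carbon. For the measured compounds named here, it therefore offers no direct guide, and the expectation for compound 4 in this assay is a number close to that of compound 2, with no step confidently predicted beyond the scatter in either direction. On that basis compound 4 is estimated at 25000 nM, within 7000 nM to 90000 nM, corresponding to an expected 1.3-fold lower number from compound 2 to compound 4 (0.11 log units; within the scatter).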

Compound 4, concentration for total growth inhibition: 7660 nM
Beside the measured number, compound 4's estimate is 3.3-fold (0.51 log units) above it; low and high end bracket the measured number.
By their numbers in this assay, from the lowest: compound 1; then compounds 4 and 3 (each within the scatter of the next); then compound 2.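

In this assay, the position on the aromatic carbon of the five-membered aromatic ring with 2 nitrogen proves responsive, as naphthalen-2-yl in place of 4-methoxyphenyl gives a 4.2-fold lower number from compound 2 to compound 4 (0.62 log units; beyond the scatter). The earlier compounds had shown a change only in the halogen, so this is the first sign that the aryl group at this position also bears on growth inhibition, with a modest step of its own. Because the entering group has no hydrogen-bond acceptor, the 4-methoxyphenyl oxygen is not required for activity at this level on the bromo compound, although this single exchange also adds a second aromatic ring and cannot separate those two changes; nothing measured here explains the step.

The compounds shown leave open whether the same exchange would carry over to the chloro compound, since the step is seen only with bromo on the shared core. They also leave open whether the second ring matters in itself, which a plain phenyl, a naphthalen-1-yl or a 4-hydroxyphenyl group at this position could help to settle.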